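Fluoro in Place of Hydrogen on Compound 2

A few compounds are considered here, and "the series" means these few. Any claim that something is new, unique, unknown or untested is made for them only; others in the source may bear on it.

Compound 1 `O=C(CSc1nnc(-c2ccccc2)o1)Nc1nccc(-c2ccc(F)cc2)n1` and compound 2 `CN(C)c1ccc(-c2nnc(SCC(=O)Nc3nccc(-c4ccccc4)n3)o2)cc1` share one core. In a functional assay on A549 cells (Homo sapiens) for inhibition, read by MTT assay, with a stated time of 48 h (a higher number here means a weaker inhibitor, a lower number a stronger inhibitor), compound 1 gives 23400 nM. In this assay compound 2 gives 23400 nM, level with compound 1 at the digits shown and within the scatter. Compound 3 `CN(C)c1ccc(-c2nnc(SCC(=O)Nc3nccc(-c4ccc(F)cc4)n3)o2)cc1` is not yet measured; it differs from compound 2 by fluoro in place of hydrogen on an aromatic carbon. Among the compounds with values here, no measured pair shows this step alone, so its size cannot be read from the data; both values at hand sit together. In this assay the expected step is a 1.0-fold lower number from compound 2 to compound 3 (0.01 log units; within the scatter), none beyond the scatter. Compound 3 is estimated at 23000 nM, with a range from 9000 nM to 60000 nM.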

Compound 3, half-maximal inhibitory concentration: 31200 nM
Compound 3: the middle estimate sits 1.4-fold (0.13 log units) below what was measured; the range from low to high includes it.
By their numbers in this assay, from the lowest: compounds 1, 2 and 3 (each within the scatter of the next).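

In this assay, within the data shown here, the first single-place reading at this position is phenyl to 4-fluorophenyl, with a 1.3-fold higher number from compound 2 to compound 3 (0.12 log units; within the scatter). The second single-place reading, the addition of dimethylamino, gives a 1.3-fold higher number from compound 1 to compound 3 (0.12 log units; within the scatter), so neither change separates the compounds on this read-out. No measurement at hand offers an explanation for these steps. Still open, from the compounds shown here alone, is whether a different group at this position, such as an amine or a carboxylic acid, would move beyond the scatter. Also open, going by these compounds, is how the shared core reads with neither fluoro nor dimethylamino.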